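The source may hold more compounds than are shown below. What is called first, only, known or untested is meant among the compounds shown, and "the series" means these compounds.

Series notes. Compound 1 `CC(=O)OCC(CCn1cc(C#CCc2ccccc2)c(=O)n(C(=O)c2ccccc2)c1=O)COC(C)=O` and compound 2 `CC(=O)OCC(CCn1cc(C#CC2CC2)c(=O)n(C(=O)c2ccccc2)c1=O)COC(C)=O` share one core and differ only by cyclopropyl in place of benzyl on a triple-bonded carbon. In a functional assay on MCF7 cells (Homo sapiens) for antiproliferative activity, read by MTT assay, with a stated time of 72 h (a lower number here means a stronger inhibitor, a higher number a weaker inhibitor), compound 1 gives 26800 nM. In this assay compound 2 gives 100 nM. That single change made a 270-fold lower number from compound 1 to compound 2 (2.43 log units; beyond the scatter).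

Compound 3 `O=c1[nH]c(=O)n(CCC(CO)CO)cc1C#CCc1ccccc1` carries the same benzyl on a triple-bonded carbon but sits on another core; the difference between the two cores is not broken down here. In this assay compound 3 gives only a limit of the assay, > 100000 nM, and not a number; it is the one case noted as the limit of > 100000 nM in this assay, at which 1 of the 3 values shown sits.

Compound 4 `O=c1[nH]c(=O)n(CCC(CO)CO)cc1C#CC1CC1` has not yet been measured. It differs from compound 3 by cyclopropyl in place of benzyl on a triple-bonded carbon, which is the same change as the measured one, at the same surroundings on the triple-bonded carbon. The starting value of compound 3 is a limit, so the size of the step cannot be anchored exactly. The carry-over between two cores whose difference is not broken down is itself uncertain, so the range is wide. Compound 4 is expected at 5000 nM, estimated to fall between 500 nM and 100000 nM. That estimate means an expected step of an at least 20-fold lower number from compound 3 to compound 4 (1.30 log units; beyond the scatter), resting on the earlier 270-fold lower number from compound 1 to compound 2 (2.43 log units; beyond the scatter) and on the limit held by compound 3, > 100000 nM.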

Compound 4, half-maximal inhibitory concentration: > 100000 nM
Compound 4 ended at the assay's limit; the forecaster's own chance of this, stated with the estimate: 30%; middle value at least 20-fold (1.30 log units) from the limit.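

In this assay compound 4 gives > 100000 nM, a limit of the assay and not a number. Compound 3 also gives a limit, > 100000 nM, so no step can be read between compound 3 and compound 4: the limit of > 100000 nM in this assay, at which 2 of the 4 values shown sit.

Still open, as far as these compounds go, is whether cyclopropyl in place of benzyl on a triple-bonded carbon changes the value at all on the core of compound 3.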